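The source may report more compounds than this note shows. Statements on the series, on what has been measured and on what is new or still open speak of the compounds shown alone.

Of the compounds shown here, three have so far been measured in a functional assay on Ehrlich cells (Mus musculus) for antiproliferative activity, read by trypan blue exclusion, with a stated time of 2 h, tested at 10 ug/mL; a lower number here means a weaker effect, a higher number a stronger effect of the compound at the concentration tested. Compound 1 `N#CC1=C(N)N(c2ccc(S(N)(=O)=O)cc2)C2=C(C(=O)CCC2)C1c1ccc(O)cc1` gives 90%, compound 2 `N#CC1=C(N)N(c2ccc(S(N)(=O)=O)cc2)C2=C(C(=O)CCC2)C1c1ccc([N+](=O)[O-])cc1` gives 85%, and compound 3 `N#CC1=C(N)N(c2ccc(S(N)(=O)=O)cc2)C2=C(C(=O)CCC2)C1c1ccc(Cl)cc1Cl` gives 40%. Compound 3 stands lowest of the three: the step of a number 50 percentage points lower from compound 1 to compound 3 (beyond the scatter) and the step of a number 45 percentage points lower from compound 2 to compound 3 (beyond the scatter) both lie beyond the scatter, whereas the step of a number 5 percentage points lower from compound 1 to compound 2 (within the scatter) lies within it, so compounds 1 and 2 cannot be told apart on these numbers.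

Compound 4 `COc1ccc(C2C(C#N)=C(N)N(c3ccc(S(N)(=O)=O)cc3)C3=C2C(=O)CCC3)c2ccccc12` has not yet been measured. It differs from compound 3 at the same saturated ring carbon that carried the earlier exchanges: 4-methoxynaphthalen-1-yl in place of 2,4-dichlorophenyl on a saturated ring carbon. The two measured steps that bear on this change are a number 50 percentage points lower from compound 1 to compound 3 (beyond the scatter) and a number 45 percentage points lower from compound 2 to compound 3 (beyond the scatter), both large and both in the same direction. Within the data shown here, no measured step shows what a 4-methoxynaphthalen-1-yl group does at this carbon; all that can be said is that two aryl groups gave high numbers and the 2,4-dichlorophenyl group alone gave a low one. Compound 4 is therefore expected to rise, by an estimated a number 25 percentage points higher from compound 3 to compound 4 (beyond the scatter), with wide uncertainty in either direction. The estimate for compound 4 in this assay is 65%, with a range from 35% to 90%.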

Compound 4, a percentage reported as activity, at one concentration (the size of the read-out at that concentration, not a potency): 10%
Beside the measured number, compound 4's estimate is 55 percentage points above it, outside the stated range (below it).
By their numbers in this assay, from the lowest: compound 4; then compound 3; then compounds 2 and 1 (each within the scatter of the next).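

In this assay, the exchange of 2,4-dichlorophenyl for 4-methoxynaphthalen-1-yl on the saturated ring carbon gives a number 30 percentage points lower from compound 3 to compound 4 (beyond the scatter), so the low number seen with the dichlorophenyl group was not the lowest this position can give. Set against the two high-scoring groups, the same carbon now spans a number 75 percentage points lower from compound 2 to compound 4 (beyond the scatter) and a number 80 percentage points lower from compound 1 to compound 4 (beyond the scatter), which makes the aryl group here a very large determinant of the read-out at the concentration tested, with the rest of the structure held constant. Nothing measured explains why the group with a second aromatic ring and a methoxy group gives the lowest number of the four compounds.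

The compounds shown leave open whether the fall belongs to the second aromatic ring or to the methoxy group, since the exchange changes both at once; a plain naphthalen-1-yl group and a 4-methoxyphenyl group would separate the two. They also leave open whether the high numbers depend on the single substituent at the 4-position of the phenyl ring, which an unsubstituted phenyl or a 4-aminophenyl group at this carbon would test.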